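Carboxy for Ethyl on the Amide Side Chain

This account rests on a few compounds, and the source may have more. Where it says the series, first, only, none or still open, it means among the compounds named here.

Compound 1 `CCCNC(=O)Cn1nc(N)c2c(C(F)(F)F)cc(-c3ccccc3)nc21` gives 16500 nM in a functional assay on A549 cells (Homo sapiens) for cytotoxicity, read by MTT assay, with a stated time of 24 h (a lower number here means a stronger inhibitor, a higher number a weaker inhibitor), the second highest of the three numbers measured. Compound 2 `Nc1nn(CC(=O)NCc2ccccc2)c2nc(-c3ccccc3)cc(C(F)(F)F)c12` gives 17300 nM, and the step of a 1.0-fold higher number from compound 1 to compound 2 (0.02 log units; within the scatter) lies within the scatter. Compound 3 `Nc1nn(CC(=O)N2CCOCC2)c2nc(-c3ccccc3)cc(C(F)(F)F)c12` gives 5400 nM, and the step of a 3.1-fold lower number from compound 1 to compound 3 (0.49 log units; beyond the scatter) is modest. Compound 4 `Nc1nn(CC(=O)NCC(=O)O)c2nc(-c3ccccc3)cc(C(F)(F)F)c12` differs from compound 1 by carboxy in place of ethyl on a saturated chain carbon bound to an amide-type nitrogen. The step that bears on it most is a 1.0-fold higher number from compound 1 to compound 2 (0.02 log units; within the scatter), where a replacement at the same saturated chain carbon changed nothing beyond the scatter. The steps to compound 3 alter the carbonyl side instead. Compound 4 is therefore expected to stay close to compound 1, with a step of a 1.0-fold higher number from compound 1 to compound 4 (0.01 log units; within the scatter). The estimated value of compound 4 is 17000 nM, with a range from 7000 nM to 42000 nM.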

Compound 4, half-maximal inhibitory concentration: 19900 nM
Compound 4: middle estimate off by 1.2-fold (0.07 log units), on the low side; measured number inside the range.
By their numbers in this assay, from the lowest: compound 3; then compounds 1, 2 and 4 (each within the scatter of the next).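

At the saturated chain carbon bound to an amide-type nitrogen, carboxy now joins ethyl and phenyl without separating from either (compound 1 step: a 1.2-fold higher number from compound 1 to compound 4 (0.08 log units; within the scatter); compound 2 step: a 1.2-fold higher number from compound 2 to compound 4 (0.06 log units; within the scatter)). Even an acid-bearing end therefore leaves the number within the scatter of the other secondary amides shown. Only morpholin-4-yl on the carbonyl carbon still stands apart (a 3.7-fold higher number from compound 3 to compound 4 (0.57 log units; beyond the scatter)).

On these data alone, whether an amine or a methyl ester in place of carboxy would also read alike remains open. So does whether piperidin-1-yl on the carbonyl carbon would match compound 3. No evidence bearing on the cause of these numbers is available.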